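Moving from 2H-tetrazol-5-yl to (1H-tetrazol-5-yl)methyl

The compounds below may be only part of what the source reports. "The series", "measured", "known", "first", "only" and "open" are said of these compounds alone.

So far two compounds have numbers to compare in a functional assay on the whole organism with Cavia porcellus as the target (on this read-out higher numbers stand for an effect only at larger amounts of compound and lower numbers for an effect already at smaller amounts), on this whole-animal test. Compound 1 `c1cc(OCc2ccc(-c3nn[nH]n3)cc2)cc(OCc2ccc3ccccc3n2)c1` gives 6.5 mg/kg and so holds the lower of the two numbers, meaning it acts at the smaller dose. Compound 2 `COc1cc(COc2cccc(OCc3ccc4ccccc4n3)c2)cc(-c2nn[nH]n2)c1` gives 38 mg/kg as the higher number, and the gap between the two lies beyond the usual scatter of repeat measurements.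

The next compound in line is compound 3 `c1cc(OCc2ccc(Cc3nnn[nH]3)cc2)cc(OCc2ccc3ccccc3n2)c1`, which has not yet been measured. It keeps the core of compound 1 and changes one group: (1H-tetrazol-5-yl)methyl stands in place of 2H-tetrazol-5-yl, on an aromatic carbon of a six-membered aromatic ring of carbon only, para to a large group ((1H-tetrazol-5-yl)methyl in place of 2H-tetrazol-5-yl on an aromatic carbon). Among the compounds with values here, no measured pair isolates a change of this kind, so any forecast is rough. Within the data shown here, compound 2 at 38 mg/kg shows only that a relative of compound 1 can need a clearly larger dose. The estimated step of a 2.2-fold higher number from compound 1 to compound 3 (0.33 log units; beyond the scatter) is a small move toward a larger dose, expected close to the edge of the scatter. Compound 3 is expected at 14 mg/kg with an estimated range from 4 mg/kg to 50 mg/kg as the upper end.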

Compound 3, dose for half-maximal effect: 6.8 mg/kg
Compound 3: middle estimate off by 2.1-fold (0.31 log units), on the high side; measured number inside the range.
By their numbers in this assay, from the lowest: compounds 1 and 3 (each within the scatter of the next); then compound 2.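

In this assay, within the data shown here, placing (1H-tetrazol-5-yl)methyl instead of 2H-tetrazol-5-yl on the aromatic carbon para to a large group gives a 1.0-fold higher number from compound 1 to compound 3 (0.02 log units; within the scatter) and is the first comparison here in which the two compounds differ in only one place. This shows that, at this place, the added methyl link does not separate the two compounds on this whole-animal read-out, while the tetrazole ring and the counted hydrogen-bond donors and acceptors stay the same. The data offer no measured reason for this match.

Going by these compounds, what happens with a longer chain between the aromatic ring and the tetrazole, such as a (1H-tetrazol-5-yl)ethyl group, or with a carboxylic acid in the same place, remains open. A single dose read-out from the whole animal also leaves open whether compound 1 and compound 3 would still match in a test of how long each compound stays in the body.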